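From a (Piperidin-1-yl)carbonyl Group to a 3-Methylbenzyl Group

A few compounds are considered here, and "the series" means these few. Any claim that something is new, unique, unknown or untested is made for them only; others in the source may bear on it.

Compound 1 `COc1cc(-c2nc3cc(/C=C4\SC(=O)N(CC(=O)N5CCCCC5)C4=O)ccc3[nH]2)cc(OC)c1OC` gives 14700 nM in a functional assay on PC-3 cells (Homo sapiens) for inhibition, read by MTT assay, with a stated time of 48 h; a lower number here means a stronger inhibitor, a higher number a weaker inhibitor.
Compound 2 `COc1cc(OC)c(-c2nc3cc(/C=C4\SC(=O)N(CC(=O)N5CCCCC5)C4=O)ccc3[nH]2)cc1OC` gives > 50000 nM in this assay.

The value of compound 2 is a limit of this assay, not a number, and compound 2 therefore stands at the weak end of the two results shown, as the limit of > 50000 nM in this assay, at which 1 of the 2 values shown sits, records. For the measured compounds named here, the only measured step, an at least 3.4-fold higher number from compound 1 to compound 2 (0.53 log units; beyond the scatter), concerns a change on the aromatic carbon and says nothing about the side chain on the ring nitrogen.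

Compound 3 `COc1cc(OC)c(-c2nc3cc(/C=C4\SC(=O)N(Cc5cccc(C)c5)C4=O)ccc3[nH]2)cc1OC` differs from compound 2 in exactly that side chain: 3-methylphenyl in place of (piperidin-1-yl)carbonyl on a saturated chain carbon bound to an amide-type nitrogen in a ring. Going by the values given here, no measured step bears on this change, so the direction cannot be read from the data. Compound 3 is expected to remain weak, near the value of compound 2, at an estimated 40000 nM (range 8000 nM to 150000 nM). The step from compound 2 to compound 3 is thus estimated as an at least 1.2-fold lower number from compound 2 to compound 3 (0.09 log units; that floor lies within the scatter), a change that may not be distinguishable from scatter.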

Compound 3, half-maximal inhibitory concentration: 630 nM
Compound 3: the middle estimate sits 63-fold (1.80 log units) above what was measured; measured number below the stated range.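

Setting 3-methylphenyl in place of (piperidin-1-yl)carbonyl on a saturated chain carbon bound to an amide-type nitrogen in a ring gives an at least 79-fold lower number from compound 2 to compound 3 (1.89 log units; beyond the scatter), so in this assay this side chain can shift the result strongly, which the earlier change on the aromatic carbon could not show. The value of compound 2 is a limit of the assay, not a number: the limit of > 50000 nM in this assay, at which 1 of the 3 values shown sits. Compound 3 keeps the 2,4,5-trimethoxyphenyl group of compound 2, so that group alone does not hold a compound at the weak end of this assay.

From the compounds shown here alone, it remains open whether the ring or its methyl group matters here, and what an unsubstituted benzyl or a longer chain ending in an amine would give at this place. Going by these compounds, it is also open how 3-methylbenzyl behaves alongside 3,4,5-trimethoxyphenyl.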